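Moving the Trifluoromethyl Group Around the Amide Ring

The source may hold more compounds than are shown below. What is called first, only, known or untested is meant among the compounds shown, and "the series" means these compounds.

Compound 1: `COC(=O)c1scc(-c2ccc(NC(=O)c3cccc(C(F)(F)F)c3)cc2)c1OC` — 24600 nM
Compound 2: `COC(=O)c1scc(-c2ccc(NC(=O)c3cc(I)ccc3F)cc2)c1OC` — 16500 nM

In a functional assay on MDA-MB-231 cells (Homo sapiens) for antiproliferative activity, read by MTT assay, with a stated time of 24 h (a higher number here means a weaker inhibitor, a lower number a stronger inhibitor), compound 2 gives 16500 nM, the lower of the two numbers; yet the step of a 1.5-fold lower number from compound 1 to compound 2 (0.17 log units; within the scatter) is within the scatter, so the two compounds cannot be told apart. Compound 3, `COC(=O)c1scc(-c2ccc(NC(=O)c3ccc(C(F)(F)F)cc3)cc2)c1OC`, carries 4-(trifluoromethyl)phenyl in place of 2-fluoro-5-iodophenyl on a carbonyl carbon. Within the data shown here, the only measured step that bears on it, a 1.5-fold lower number from compound 1 to compound 2 (0.17 log units; within the scatter), was small, and compound 3 shares its trifluoromethyl ring with compound 1. Compound 3 is therefore expected to show a step of a 1.3-fold higher number from compound 2 to compound 3 (0.12 log units; within the scatter) that stays within the scatter. The estimate for compound 3 is 22000 nM, in the range 9000 nM to 55000 nM.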

Compound 3, half-maximal inhibitory concentration: 18300 nM
The estimate for compound 3 lay 1.2-fold (0.08 log units) above the measured number; the range from low to high includes it.
By their numbers in this assay, from the lowest: compounds 2, 3 and 1 (each within the scatter of the next).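

Placing 4-(trifluoromethyl)phenyl in place of 3-(trifluoromethyl)phenyl on the carbonyl carbon gives (a 1.3-fold lower number from compound 1 to compound 3 (0.13 log units; within the scatter)), so in (this assay) the two trifluoromethyl rings cannot be told apart. Replacing 2-fluoro-5-iodophenyl with 4-(trifluoromethyl)phenyl gives (a 1.1-fold higher number from compound 2 to compound 3 (0.04 log units; within the scatter)), which leaves all three compounds indistinguishable in this assay. No measurement is available to explain this flat result. Still open, from the compounds shown here alone, is whether a ring carrying an amine or a carboxylic acid would give a number beyond the scatter.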